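Clearance notes: pyrimidine amide on the aminopyridine core

The compounds below may be only part of what the source reports. "The series", "measured", "known", "first", "only" and "open" are said of these compounds alone.

Compound 1 `C[C@H](NC(=O)c1cccc(F)c1)c1ccc(NC(=O)N2CC(c3cccnc3)C2)cc1` gives 60.9 mL.min-1.g-1 in an ADME assay on microsomes from liver (Mus musculus) for pharmacokinetics, read by LC-MS, using NADPH, with stated times of 5 min, 15 min and 30 min, tested at 10 uM; a lower number here means slower removal, a higher number faster removal of the compound. Compound 2 `C[C@H](NC(=O)c1ncccn1)c1ccc(NC(=O)N2CC(c3cccnc3)C2)cc1` gives 28.9 mL.min-1.g-1 in this assay, and the change pyrimidin-2-yl in place of 3-fluorophenyl on a carbonyl carbon made a 2.1-fold lower number from compound 1 to compound 2 (0.32 log units; beyond the scatter). Compound 3 `C[C@H](NC(=O)c1cccc(F)c1)c1ccc(NC(=O)N2CC(c3cncc(N)c3)C2)cc1` gives 27.4 mL.min-1.g-1 in this assay; its core differs from that of compound 1 by amino in place of hydrogen on an aromatic carbon, and this made a 2.2-fold lower number from compound 1 to compound 3 (0.35 log units; beyond the scatter). The values of compound 2 and compound 3 lie within the scatter of each other.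

Compound 4 `C[C@H](NC(=O)c1ncccn1)c1ccc(NC(=O)N2CC(c3cncc(N)c3)C2)cc1` is not yet measured in this assay. It differs from compound 3 by pyrimidin-2-yl in place of 3-fluorophenyl on a carbonyl carbon, the same change as from compound 1 to compound 2, at the same place. Because that change gave a 2.1-fold lower number from compound 1 to compound 2 (0.32 log units; beyond the scatter), compound 4 is expected to show a 1.8-fold lower number from compound 3 to compound 4 (0.26 log units; within the scatter). On these data alone, whether the two changes add fully on one core is untested here, so the range is kept wide. In this assay compound 4 is estimated at 15 mL.min-1.g-1, expected between 8 mL.min-1.g-1 and 30 mL.min-1.g-1.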

Compound 4, intrinsic clearance in microsomes: 83.4 mL.min-1.g-1
Compound 4: the middle estimate sits 5.6-fold (0.75 log units) below what was measured; the whole stated range lies below it.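

On the core of compound 3, pyrimidin-2-yl in place of 3-fluorophenyl gives a 3.0-fold higher number from compound 3 to compound 4 (0.48 log units; beyond the scatter), so in this assay this step does not carry over from the core of compound 1: the same change on two cores in this assay, a 2.1-fold lower number (0.32 log units; beyond the scatter) from compound 1 to compound 2 and a 3.0-fold higher number (0.48 log units; beyond the scatter) from compound 3 to compound 4, 6.4-fold (0.81 log units) apart, beyond the scatter of two such steps

Amino in place of hydrogen likewise gives a 2.9-fold higher number from compound 2 to compound 4 (0.46 log units; beyond the scatter), against its step on the 3-fluorophenyl amide: the same change on two cores in this assay, a 2.2-fold lower number (0.35 log units; beyond the scatter) from compound 1 to compound 3 and a 2.9-fold higher number (0.46 log units; beyond the scatter) from compound 2 to compound 4, 6.4-fold (0.81 log units) apart, beyond the scatter of two such steps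

The two changes therefore do not act independently across these four compounds, but this rests on one pair per change and does not show what reverses the direction.

Open, on these data alone, is whether the reversal needs the amino group itself or also appears with a methoxy group on that aromatic carbon. Also open, as far as these compounds go, is whether a pyridin-2-yl on the carbonyl carbon behaves as pyrimidin-2-yl does in compound 4.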